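From compound 1 to compound 3: a changed attachment

The compounds below may be only part of what the source reports. "The series", "measured", "known", "first", "only" and "open" are said of these compounds alone.

Compound 1 (`C=CC(=O)Nc1ccc(Cn2nc(-c3ccc(Oc4ccccc4)cc3)cc2C(=O)O)cc1`) reads > 60000 nM in a functional assay on Rec1 cells (Homo sapiens) for inhibition, read by luminescence and CellTiter-Glo, with a stated time of 72 h; on this read-out higher numbers stand for weaker inhibition and lower numbers for stronger inhibition. That reading is a limit of the assay, not a number. Compound 2 (`C=CC(=O)Nc1ccc(Cn2nc(-c3ccc(Oc4ccccc4)cc3)cc2C(=O)OCC)cc1`) gives 2800 nM in this assay. Among the measured compounds shown here, the only measured step, an at least 21-fold lower number from compound 1 to compound 2 (1.33 log units; beyond the scatter), is large but lies at another place in the molecule. Compound 3 (`C=CC(=O)Nc1cccc(Cn2nc(-c3ccc(Oc4ccccc4)cc3)cc2C(=O)O)c1`) differs from compound 1 as follows: 3-((vinylcarbonyl)amino)phenyl in place of 4-((vinylcarbonyl)amino)phenyl on a saturated chain carbon bound to an aromatic nitrogen. For the measured compounds named here, no measured step covers this place, so none gives a size to carry over. The step expected in this assay is a number no higher from compound 1 to compound 3 (the limit leaves the size open), with none beyond the scatter anticipated. For compound 3 the estimate is 60000 nM, with an expected range of 25000 nM to 120000 nM.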

Compound 3, half-maximal inhibitory concentration: 33100 nM
The estimate for compound 3 lay 1.8-fold (0.26 log units) above the measured number; low and high end bracket the measured number.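

With the 3-((vinylcarbonyl)amino)phenyl group, the carboxylic acid series gains its first reading that is a number rather than a limit, which gives this position a usable reference point. In this assay, the change of attachment gives an at least 1.8-fold lower number from compound 1 to compound 3 (0.25 log units; that floor lies within the scatter), so no gain beyond the scatter can be claimed. The true size stays open, since the reading for compound 1 is a limit of the assay: the limit of > 60000 nM in this assay, at which 1 of the 3 values shown sits.

Still open, going by these compounds, is how the 3-((vinylcarbonyl)amino)phenyl group reads when combined with the ethyl ester of compound 2. Also open, on these data alone, is how a primary amide reads in place of the carboxylic acid.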